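A few compounds are considered here, and "the series" means these few. Any claim that something is new, unique, unknown or untested is made for them only; others in the source may bear on it.

Compound 1 `C[C@H](Nc1ncnc2[nH]cnc12)c1cc2ccccn2c(=O)c1-c1ccccc1` and compound 2 `C[C@H](Nc1ncnc2[nH]cnc12)c1cc2ccc(F)cn2c(=O)c1-c1ccccc1` share one core, while compound 3 `C[C@H](Nc1ncnc(N)c1C#N)c1cc(=O)n2cc(F)ccc2c1-c1ccccc1` and compound 4 `C[C@H](Nc1ncnc(N)c1C#N)c1cc(=O)n2cc(F)ccc2c1-c1cccc(F)c1` share another; the difference between the two cores is not broken down here. In an ADME assay on microsomes from liver (Rattus norvegicus), read by LC-MS, using NADPH, with a stated time of 30 min, tested at 1 uM (on this read-out higher numbers stand for a more stable compound and lower numbers for a less stable compound), compound 1 gives 93%, and compound 2 gives 95%. The change between them is fluoro in place of hydrogen on an aromatic carbon, and it brought a number 2 percentage points higher from compound 1 to compound 2 (within the scatter). In this assay compound 3 gives 74%, a value that stands beyond the scatter below both compound 1 and compound 2.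

Compound 4 is not yet measured. It arises from compound 3 by fluoro in place of hydrogen on an aromatic carbon. Among the compounds with values here, this is the same kind of change as the one from compound 1 to compound 2, but the place differs: earlier the fluoro entered a six-membered aromatic ring with one nitrogen, part of a fused or bridged system of two rings, two atoms from the ring nitrogen, meta to a fused ring and para to a fused ring; now it enters a six-membered aromatic ring of carbon only, meta to a large group.

The earlier step stayed within the scatter, so a similarly small step is expected, namely a number 2 percentage points higher from compound 3 to compound 4 (within the scatter). Compound 4 is therefore estimated at 76%, with a range from 60% to 90%.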

Compound 4, percent of the compound remaining: 79%
Estimate against measurement, compound 4: 3 percentage points below; measured number inside the range.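

In this assay, putting fluoro in place of hydrogen on an aromatic carbon brought a number 5 percentage points higher from compound 3 to compound 4 (within the scatter). Set beside the earlier step, this kind of change behaves alike on the two cores: the same change on two cores in this assay, a number 2 percentage points higher (within the scatter) from compound 1 to compound 2 and a number 5 percentage points higher (within the scatter) from compound 3 to compound 4, 3 percentage points apart, within the scatter of two such steps. This shows that the swap of hydrogen for fluoro left the percent remaining within the usual scatter in both pairs, but it does not show that the two steps are the same replacement, as the fluoro enters a six-membered aromatic ring with one nitrogen in compound 2 and a six-membered aromatic ring of carbon only in compound 4, and two pairs give no rule for other cores.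

The compounds shown leave open whether a different group in the place taken by fluoro in compound 4, such as chloro, methoxy or an amine, would also stay within the scatter. They also leave open whether fluoro elsewhere on that phenyl ring would do the same.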